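The source may report more compounds than this note shows. Statements on the series, on what has been measured and on what is new or still open speak of the compounds shown alone.

Within the data shown here, compound 1 `Cc1ccc(NC2=CC(=O)c3c(nc4n3[C@H]3OC[C@@H](O)[C@H]3OC4)C2=O)cc1C` is the only member of the series with a number rather than a limit: in a functional assay on MCF7 cells (Homo sapiens) for inhibition, read by sulforhodamine B assay (a lower number here means a stronger inhibitor, a higher number a weaker inhibitor), compound 1 gives 4950 nM. Compound 2 `O=C1C=C(NC2CCCC2)C(=O)c2c1nc1n2[C@H]2OC[C@@H](O)[C@H]2OC1` reaches only a limit in this assay, > 16000 nM. Compound 3 `O=C1C=C(N2CCCCC2)C(=O)c2c1nc1n2[C@H]2OC[C@@H](O)[C@H]2OC1` likewise reaches only a limit in this assay, > 8000 nM. Among the measured compounds shown here, the one step between measured compounds, a step that the two limits leave unreadable from compound 2 to compound 3, has no readable size. Compound 4 `O=C1C(Nc2ccc(C(F)(F)F)cc2)=CC(=O)c2c1nc1n2[C@H]2OC[C@@H](O)[C@H]2OC1` is not yet measured; it differs from compound 1 in one place: 4-(trifluoromethyl)phenyl in place of 3,4-dimethylphenyl on an amine nitrogen. For the measured compounds named here, no measured step concerns an aryl group on the amine nitrogen; the step from cyclopentylamino to piperidin-1-yl runs between two limits and carries no size. The expectation therefore rests on compound 1 alone, and the step of a 1.2-fold higher number from compound 1 to compound 4 (0.08 log units; within the scatter) is expected to stay within the scatter of repeated measurement, with no direction that the data can support. Compound 4 is estimated at 6000 nM in this assay, between 2500 nM and 16000 nM.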

Compound 4, half-maximal inhibitory concentration: > 4000 nM
Compound 4 ended at the assay's limit; the forecaster's own chance of this, stated with the estimate: 20%; the middle value does not contradict the limit.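

The step from compound 1 to compound 4 cannot be read, as compound 4 reaches only a limit in this assay. The compounds shown leave open whether 4-(trifluoromethyl)phenyl and 3,4-dimethylphenyl on the amine nitrogen differ at all in inhibition.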